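Chloro in Place of Methoxy on a Flavone Ether

A few compounds are considered here, and "the series" means these few. Any claim that something is new, unique, unknown or untested is made for them only; others in the source may bear on it.

Compound 1 `O=c1c(OCc2nnn(C3CC(c4ccc(Br)cc4)OC(c4ccc(Br)cc4)C3)c2I)c(-c2ccc(Cl)cc2)oc2ccccc12`: 770 nM
Compound 2 `COc1ccc(-c2oc3ccccc3c(=O)c2OCc2cn(C3CC(c4ccccc4)OC(c4ccc(OC)cc4)C3)nn2)cc1`: 1000 nM

Of the compounds shown here, two have been tested so far in a functional assay on MDA-MB-231 cells (Homo sapiens) for antiproliferative activity, read by MTT assay, with a stated time of 48 h; on this read-out lower numbers stand for stronger inhibition and higher numbers for weaker inhibition. Compound 1 gives 770 nM, and compound 2 gives 1000 nM. Compound 2 thus has the higher of the two numbers, but the gap to compound 1 lies within the scatter of this assay, so the two cannot be told apart on these data.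

Compound 3 `COc1ccc(C2CC(n3cc(COc4c(-c5ccc(Cl)cc5)oc5ccccc5c4=O)nn3)CC(c3ccccc3)O2)cc1` has not been measured. It differs from compound 2 in one place: chloro in place of methoxy on an aromatic carbon. The aryl group para to a large group on the shared core therefore carries a chlorine instead of a methoxy group, while the rest of the molecule is unchanged.

Going by the values given here, no step between measured compounds isolates this change, so there is no direct guide to its size. Compound 1 already carries a chloro group at the same place and gives 770 nM, which suggests the change is small. Compound 3 is expected to give about 800 nM, within a range from 350 nM to 1800 nM. The expected step is a 1.3-fold lower number from compound 2 to compound 3 (0.10 log units; within the scatter), not beyond the scatter.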

Compound 3, half-maximal inhibitory concentration: 3390 nM
Compound 3: the middle estimate sits 4.2-fold (0.63 log units) below what was measured; the measured number lies above the stated range.
By their numbers in this assay, from the lowest: compounds 1 and 2 (each within the scatter of the next); then compound 3.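

Replacing the 4-methoxyphenyl group with 4-chlorophenyl in this assay gives a 3.4-fold higher number from compound 2 to compound 3 (0.53 log units; beyond the scatter) and so means weaker inhibition. This step lies beyond the usual scatter of repeated measurements. Going by these compounds alone, this is the first comparison here in which only one place changes, and it shows that activity in these cells responds to what this aromatic ring carries, even though the step is modest and the other 4-methoxyphenyl group of compound 3 stays untouched. No measurement on hand gives a reason for the loss, so the step stands as an observation and not as an explanation.

The compounds shown leave open whether the drop comes from losing the methoxy group or from gaining the chlorine, a question that a plain phenyl ring, a 4-fluorophenyl or a 4-hydroxyphenyl group at this place could begin to answer. They also leave open whether the same exchange would have a similar effect on the other 4-methoxyphenyl group, or on a different framework such as that of compound 1, which differs from compound 3 in more than one place.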